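The source may hold more compounds than are shown below. What is called first, only, known or untested is meant among the compounds shown, and "the series" means these compounds.

Measured in a functional assay on HEL cells (Homo sapiens); a higher number here means that more compound is tolerated, a lower number that less compound is tolerated:
Compound 1, `O=C1c2ccccc2NS(=O)(=O)N1Cc1ccccc1`: compound 1 gives > 50 ug/mL, which is a limit of the assay rather than a number.
Compound 2, `C#CCOCN1C(=O)c2ccccc2NS1(=O)=O`: compound 2 gives 169 ug/mL.
Compound 3, `CC(=O)OCCOCN1c2ccccc2C(=O)N(Cc2ccccc2)S1(=O)=O`: compound 3 gives 100 ug/mL.

Compound 3 stands alongside compound 2, the two numbers lying within the scatter of each other, while compound 1 contributes only a limit. The steps a step that the limit leaves unreadable from compound 1 to compound 2 and a step that the limit leaves unreadable from compound 1 to compound 3 cannot be sized because of the limit of > 50 ug/mL in this assay, at which 1 of the 3 values shown sits. Compound 4, `O=C(OCCOCN1c2ccccc2C(=O)N(Cc2ccccc2)S1(=O)=O)c1ccccc1`, differs from compound 3 by phenyl in place of methyl on a carbonyl carbon. Among the measured compounds shown here, no measured step exchanges methyl for phenyl on a carbonyl carbon, so nothing here points in either direction, and the step from compound 3 to compound 4 is expected to stay within the scatter, no change at the digits printed from compound 3 to compound 4 (within the scatter). Compound 4 is therefore estimated at 100 ug/mL, between 40 ug/mL and 250 ug/mL.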

Compound 4, half-maximal cytotoxic concentration: 17 ug/mL
The estimate for compound 4 lay 5.9-fold (0.77 log units) above the measured number, outside the stated range (below it).
By their numbers in this assay, from the lowest: compound 4; then compounds 3 and 2 (each within the scatter of the next).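

On the carbonyl carbon of this side chain, the group clearly matters: in this assay, phenyl in place of methyl gives a 5.9-fold lower number from compound 3 to compound 4 (0.77 log units; beyond the scatter), so less compound is tolerated. Among the compounds shown here, the earlier steps from compound 1 cannot be read, which leaves this as the only sized change here. Nothing shown here accounts for this drop.

As far as these compounds go, whether it depends on the aromatic ring or simply on having more carbon atoms remains open. A cyclohexyl group, a longer chain such as propyl, or an amine on the phenyl ring could help separate these possibilities.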